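From compound 3 to compound 4 at the assay limit

The source may hold more compounds than are shown below. What is called first, only, known or untested is meant among the compounds shown, and "the series" means these compounds.

In a functional assay on PANC-1 cells (Homo sapiens) for inhibition, read by MTT assay, with a stated time of 72 h (a higher number here means a weaker inhibitor, a lower number a stronger inhibitor), compound 1 `Cc1ccc(C(=O)Nc2cccc3cccnc23)cn1` gives > 10000 nM as a limit and not a number. Compound 2 `O=C(Nc1cccc2cccnc12)c1cccnn1` gives > 10000 nM as a limit as well. Compound 3 `Cc1cnc(C(=O)Nc2cccc3ccc(C)nc23)cn1` also gives > 10000 nM as a limit, so it offers no number to measure from. Within the data shown here, the series so far therefore stands at the limit of > 10000 nM in this assay, at which 3 of the 3 values shown sit, and shows no measured step. Compound 4 `Cc1ccc2cccc(NC(=O)c3ncccn3)c2n1` carries pyrimidin-2-yl in place of 5-methylpyrazin-2-yl on a carbonyl carbon. In this assay the estimated step that the limit leaves unreadable from compound 3 to compound 4 is expected to stay within the scatter, with no direction favoured. Compound 4 is expected near 12000 nM with an estimated range from 4000 nM to 30000 nM and will most likely be reported as a limit.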

Compound 4, half-maximal inhibitory concentration: > 10000 nM
Compound 4: no number, only a limit; the forecaster's own chance of this, stated with the estimate: 85%; the middle value is on the limit's open side.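

In this assay compound 4 gives > 10000 nM, which is a limit and not a number. Compound 3 also stands at a limit, so no step can be read between compound 3 and compound 4. The compounds shown leave open whether any change to this series gives a measurable value.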